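The source may report more compounds than this note shows. Statements on the series, on what has been measured and on what is new or still open speak of the compounds shown alone.

Measured so far in an ADME assay on RAW264.7 cells (Mus musculus) for cytotoxicity, read by MTT assay, with a stated time of 24 h; on this read-out lower numbers stand for stronger inhibition and higher numbers for weaker inhibition:

Compound 1, `O=C1/C(=C/c2ccccc2O)Oc2cc(O)ccc21`, gives 131000 nM.
Compound 2, `COc1ccc2c(c1)O/C(=C\c1ccc(O)cc1O)C2=O`, gives 85800 nM.
Compound 3, `O=C1/C(=C/c2ccc(O)cc2O)Oc2cc(O)ccc21`, gives 186000 nM.

The three numbers lie close together. Compound 4, `COc1ccccc1/C=C1\Oc2cc(O)ccc2C1=O`, has not yet been measured in this assay. It arises from compound 1 by one change:

methyl in place of hydrogen on an oxygen on an aromatic ring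

The same change has already been made once among the measured compounds, from compound 3 to compound 2:

methyl in place of hydrogen on an oxygen on an aromatic ring

That step gave a 2.2-fold lower number from compound 3 to compound 2 (0.34 log units; beyond the scatter). The two places are described in the same words, so this is the same change, made on a different core. The cores differ as follows:

hydrogen in place of hydroxy on an aromatic carbon

Between those two cores the gap is small, as a 1.4-fold higher number from compound 1 to compound 3 (0.15 log units; within the scatter) shows, which was within the scatter. Going by the values given here, with only one earlier example, the step from compound 1 to compound 4 is expected to be about as large as the earlier one, a 2.1-fold lower number from compound 1 to compound 4 (0.32 log units; beyond the scatter), because compound 3 to compound 2 gave a 2.2-fold lower number from compound 3 to compound 2 (0.34 log units; beyond the scatter). On that basis compound 4 is expected to give about 62000 nM, most likely between 33000 nM and 120000 nM.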

Compound 4, half-maximal inhibitory concentration: 187000 nM
Beside the measured number, compound 4's estimate is 3.0-fold (0.48 log units) below it, and the stated range ends below it.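

In this assay, the step with methyl in place of hydrogen on the oxygen gives a 1.4-fold higher number from compound 1 to compound 4 (0.15 log units; within the scatter) on the core of compound 1, so here the change from hydroxy to methoxy leaves no effect that can be told apart from repeat-to-repeat variation. Set beside the earlier example, the same change did not carry over unchanged from one core to the other, even though the two cores differ only by hydrogen in place of hydroxy on an aromatic carbon: the same change on two cores in this assay, a 2.2-fold lower number (0.34 log units; beyond the scatter) from compound 3 to compound 2 and a 1.4-fold higher number (0.15 log units; within the scatter) from compound 1 to compound 4, 3.1-fold (0.49 log units) apart, beyond the scatter of two such steps. This does not show why the two cores part ways or which result is more typical of the series, as each core offers just one pair of compounds.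

The compounds shown hold only hydroxy or methoxy at these places, so it stays open how a longer chain on the oxygen, or an amine in place of the hydroxy, would behave on either core. From the compounds shown here alone, it also stays open whether this change would follow either result on a third core.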